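The compounds below may be only part of what the source reports. "The series", "measured", "known", "first", "only" and "open" are said of these compounds alone.

Of the compounds shown here, three sharing one core have been read in a functional assay on MCF7 cells (Homo sapiens) for cytotoxicity, read by MTT assay, with a stated time of 48 h; on this read-out higher numbers stand for weaker inhibition and lower numbers for stronger inhibition. Compound 1 `COc1ccc(Nc2nc(-c3cccc(F)c3)nc3ccc(F)cc23)cc1` gives 48400 nM. Compound 2 `Oc1ccc(Nc2nc(-c3cccc(F)c3)nc3ccc(F)cc23)cc1` gives > 50000 nM, which is a limit of the assay and not a number. Compound 3 `Oc1ccccc1Nc1nc(-c2cccc(F)c2)nc2ccc(F)cc12` gives > 50000 nM, and this too is a limit, so compound 3 stands at the limit of > 50000 nM in this assay, at which 2 of the 3 values shown sit. The move to compound 4 `Nc1ccc(Nc2nc(-c3cccc(F)c3)nc3ccc(F)cc23)cc1` is 4-aminophenyl in place of 2-hydroxyphenyl on a nitrogen on an aromatic ring. For the measured compounds named here, no measured step makes this exact exchange of 2-hydroxyphenyl for 4-aminophenyl. Going by the values given here, two measured steps bear on it, an at least 1.0-fold higher number from compound 1 to compound 2 (0.01 log units; that floor lies within the scatter) and an at least 1.0-fold higher number from compound 1 to compound 3 (0.01 log units; that floor lies within the scatter), and neither goes beyond the scatter, so no step beyond the scatter is expected in this assay. The third, a step that the two limits leave unreadable from compound 2 to compound 3, offers no size to work from. The step expected here is an at least 1.1-fold lower number from compound 3 to compound 4 (0.07 log units; that floor lies within the scatter). The estimate for compound 4 is 42000 nM. The expected range for compound 4 runs from 18000 nM to 60000 nM.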

Compound 4, half-maximal inhibitory concentration: > 50000 nM
Compound 4 ended at the assay's limit; the forecaster's own chance of this, stated with the estimate: 55%; middle value at least 1.1-fold (0.07 log units) from the limit.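

In this assay compound 4 also ends at a limit and not at a number, so 4-aminophenyl on this nitrogen gives no readable gain over the two hydroxyphenyl groups, and a nitrogen-bearing group now joins them there: the limit of > 50000 nM in this assay, at which 3 of the 4 values shown sit.

Against compound 1, the one readable comparison for amino in place of methoxy on an aromatic carbon is an at least 1.0-fold higher number from compound 1 to compound 4 (0.01 log units; that floor lies within the scatter). The steps linking compound 4 to compound 2 and to compound 3 cannot be read, with limits at both ends.

As far as these compounds go, the true order of compound 2, compound 3 and compound 4 stays open, as all three sit at the limit. Also open, from the compounds shown here alone, is whether a carboxylic acid or a longer chain in place of the amino group would give a number clearly under that limit.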